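The compounds below may be only part of what the source reports. "The series", "measured", "known", "first", "only" and "open" are said of these compounds alone.

Compound 1 `Cc1ccc(Cn2c(=O)[nH]c3c(N)nc(C(F)(F)F)cc32)cn1` and compound 2 `Cc1cccc(Cn2c(=O)[nH]c3c(N)nc(C(F)(F)F)cc32)n1` share a core and differ only in the pendant ring, and compound 3 `CN1CCN(c2ccc(Cn3c(=O)[nH]c4c(N)nc(C(F)(F)F)cc43)cn2)CC1` carries a larger group on that ring. In an in vitro ADME assay on microsomes from liver (Homo sapiens) for metabolic stability (a lower number here means slower removal, a higher number faster removal of the compound), compound 1 gives < 7 mL.min-1.g-1, which is a limit of the assay rather than a number. In this assay compound 2 likewise gives < 8 mL.min-1.g-1, again a limit rather than a number. In this assay compound 3 gives 30 mL.min-1.g-1. Compound 2 therefore stands only at a limit, and of the other two values shown one more is a limit, (the limit of < 7 mL.min-1.g-1 in this assay, at which 1 of the 3 values shown sits), while the other is a measured number. The step that the two limits leave unreadable from compound 1 to compound 2 cannot be read because both ends are limits, (the limit of < 8 mL.min-1.g-1 in this assay, at which 1 of the 3 values shown sits). The step of an at least 4.2-fold higher number from compound 1 to compound 3 (0.63 log units; beyond the scatter) shows that a larger group on the pendant ring moved the number upward.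

Compound 4 `Nc1ccc(Cn2c(=O)[nH]c3c(N)nc(C(F)(F)F)cc32)cn1` is the next compound, with 6-aminopyridin-3-yl in place of 6-methylpyridin-2-yl on a saturated chain carbon bound to an aromatic nitrogen. Among the compounds with values here, no measured step covers this exact change; the ring is repositioned and an amine replaces the methyl. Within the data shown here, the only guide is compound 3, whose step an at least 4.2-fold higher number from compound 1 to compound 3 (0.63 log units; beyond the scatter) went upward, so a modest rise from the limit is expected for compound 4, with a step of an at least 1.1-fold higher number from compound 2 to compound 4 (0.05 log units; that floor lies within the scatter). Compound 4 is thus estimated at 9 mL.min-1.g-1, between 4 mL.min-1.g-1 and 22 mL.min-1.g-1.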

Compound 4, intrinsic clearance in microsomes: < 7 mL.min-1.g-1
Compound 4: no number, only a limit; the forecaster's own chance of this, stated with the estimate: 40%; middle value at least 1.2-fold (0.10 log units) away from the limit.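

In this assay compound 4 gives < 7 mL.min-1.g-1, which is a limit of the assay and not a number, so 6-aminopyridin-3-yl in place of 6-methylpyridin-2-yl on a saturated chain carbon bound to an aromatic nitrogen does not lift the read-out clear of the limit. Amino in place of 4-methylpiperazin-1-yl on an aromatic carbon gives an at least 4.2-fold lower number from compound 3 to compound 4 (0.63 log units; beyond the scatter), so among the compounds shown, the one measured number belongs to the compound that carries 4-methylpiperazin-1-yl, while methyl and amino at that place both leave only limits. The steps that join compound 4 to compound 1 and to compound 2 cannot be read, because both ends of each step are limits: the limit of < 7 mL.min-1.g-1 in this assay, at which 2 of the 4 values shown sit.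

The compounds shown leave open how far compound 1, compound 2 and compound 4 actually lie apart, since none of the three has a number. They also leave open whether a morpholine ring or a piperazine without its methyl, set on that aromatic carbon, would stay at the limit or give a number nearer to that of compound 3.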